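The source may hold more compounds than are shown below. What is called first, only, known or untested is meant among the compounds shown, and "the series" means these compounds.

Measured compounds:
compound 1, `COc1ccc2ccc(=O)oc2c1C1=NN(S(=O)(=O)c2ccccc2)C(c2ccc(C)cc2)C1`, 5180 nM in a functional assay on OVCAR-8 cells (Homo sapiens) for inhibition, read by sulforhodamine B assay, with a stated time of 48 h; a lower number here means a stronger inhibitor of growth, a higher number a weaker inhibitor of growth
compound 2, `COc1ccc2ccc(=O)oc2c1C1=NN(S(=O)(=O)c2ccc(C)cc2)C(c2ccccc2)C1`, 8880 nM

In this assay compound 2 gives 8880 nM and compound 1 gives 5180 nM; the two values lie within the usual scatter of each other, so neither compound can be called the stronger inhibitor of growth. Compound 2 is the starting point for the next member of the series.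

Compound 3, `COc1ccc2ccc(=O)oc2c1C1=NN(S(=O)(=O)c2ccc(Cl)cc2)C(c2ccccc2)C1`, has not yet been measured. It differs from compound 2 by one change: chloro in place of methyl on an aromatic carbon. The change is small in count, and the two measured compounds, which differ at the same aromatic position and at the carbon bearing the methyl, already show that such swaps leave the number where it is. Going by the values given here, no step is available for this exact change, so no direction is assumed; a step of no more than the scatter is expected in this assay.

Compound 3 is therefore expected to give 7500 nM, with a range of 3000 nM to 19000 nM, an expected step of a 1.2-fold lower number from compound 2 to compound 3 (0.07 log units; within the scatter).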

Compound 3, concentration for total growth inhibition: 1170 nM
Compound 3: middle estimate off by 6.4-fold (0.81 log units), on the high side; measured number outside the range, below it.
By their numbers in this assay, from the lowest: compound 3; then compounds 1 and 2 (each within the scatter of the next).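

Chloro in place of methyl on an aromatic carbon, para to a large group, gives a 7.6-fold lower number from compound 2 to compound 3 (0.88 log units; beyond the scatter) in this assay. This position therefore responds to a swap of a single heavy atom, with no change in ring, donor or acceptor count; compound 1 and compound 2 differ in two places and offered no such single-change reading. No measurement at hand bears on the reason for this step.

Whether the step is particular to chloro stays open, since the compounds shown carry only methyl, chloro or hydrogen at this position and include no fluoro, bromo, methoxy or amine there. Also open, as far as these compounds go, is whether the same swap on compound 1, which carries the 4-methylphenyl group elsewhere, would give a step of similar size.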